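Methylthiophene isomer step from compound 1 to compound 4

The compounds below may be only part of what the source reports. "The series", "measured", "known", "first", "only" and "open" are said of these compounds alone.

Among the compounds with values here, in a functional assay on HUVEC cells (Homo sapiens), read by BrdU incorporation, with a stated time of 72 h (on this read-out higher numbers stand for weaker inhibition and lower numbers for stronger inhibition), compound 1 `Cc1ccc2nc(Cl)c(/C=C/C(=O)c3sccc3C)cc2c1` gives 127 nM and compound 3 `Cc1cccc2cc(/C=C/C(=O)c3ccc(Br)s3)c(Cl)nc12` gives 243 nM as the only other number so far. These two values lie within the scatter of each other, so compound 1 stands level with compound 3 on the data in hand. Compound 2 `Cc1cc(C(=O)/C=C/c2cc3cccc(C)c3nc2Cl)c(C)s1` adds no number, its entry being "not determined" (no result reported) here.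

Compound 4 `Cc1csc(C(=O)/C=C/c2cc3cc(C)ccc3nc2Cl)c1` has the same atoms as compound 1, joined differently: 4-methylthiophen-2-yl stands in place of 3-methylthiophen-2-yl on a carbonyl carbon (4-methylthiophen-2-yl in place of 3-methylthiophen-2-yl on a carbonyl carbon). Within the data shown here, no measured pair shows a change in one place, so the expectation rests on little. With compound 1 at 127 nM and compound 3 at 243 nM inside the scatter, no step beyond the scatter is expected in this assay for this change. The expected step runs a 1.3-fold higher number from compound 1 to compound 4 (0.13 log units; within the scatter) and stays a small one. For compound 4 the estimated value is 170 nM with an expected range of 65 nM to 450 nM in this read-out.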

Compound 4, half-maximal inhibitory concentration: 106 nM
Compound 4: middle estimate off by 1.6-fold (0.21 log units), on the high side, within the range that was stated.
By their numbers in this assay, from the lowest: compounds 4, 1 and 3 (each within the scatter of the next, the first and the last beyond it).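

In this assay, within the data shown here, the swap of 3-methylthiophen-2-yl for 4-methylthiophen-2-yl on the carbonyl carbon gives the first step that changes one place only: a 1.2-fold lower number from compound 1 to compound 4 (0.08 log units; within the scatter) and no more. On this read-out the two methylthiophene isomers cannot be told apart, so this position on the shared core accepts either arrangement of the same atoms. No measured data bear on why the two isomers read alike.

All the groups shown on the carbonyl carbon are thiophenes, so it stays open whether a plain phenyl ring, or a thiophene carrying an amine or a carboxylic acid, would hold the number at this position. From the compounds shown here alone, it also stays open whether the same isomer swap reads alike on a core other than that of compound 1.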